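Swapping sulfamoyl for methanesulfonamido on a shared core

The source may hold more compounds than are shown below. What is called first, only, known or untested is meant among the compounds shown, and "the series" means these compounds.

Of the compounds shown here, three sharing one core have been measured in an ADME assay on CHO cells (Cricetulus griseus) for cytotoxicity, read by MTT assay; on this read-out lower numbers stand for stronger inhibition and higher numbers for weaker inhibition. Compound 3 `NS(=O)(=O)c1cccc(-c2ccc3nccc(-c4ccncc4)c3n2)c1` gives 2000 nM, the lowest of the three numbers. Compound 2 `O=S(=O)(c1cccc(-c2ccc3nccc(-c4ccncc4)c3n2)c1)N1CCC(O)CC1` gives 8000 nM, and compound 1 `O=S(=O)(NCC1COC1)c1cccc(-c2ccc3nccc(-c4ccncc4)c3n2)c1` gives 16000 nM. These last two differ by a 2.0-fold lower number from compound 1 to compound 2 (0.30 log units; within the scatter), so they cannot really be told apart.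

Compound 4 `CS(=O)(=O)Nc1cccc(-c2ccc3nccc(-c4ccncc4)c3n2)c1` has not been measured yet. It carries methanesulfonamido in place of sulfamoyl on an aromatic carbon, at a place meta to a large group.

Among the compounds with values here, no measured step makes this exact swap, so the evidence is indirect. The closest guide is what happened when the sulfonamide group itself was altered. The change to the bare amino form gave a 4.0-fold lower number from compound 2 to compound 3 (0.60 log units; beyond the scatter) and an 8.0-fold lower number from compound 1 to compound 3 (0.90 log units; beyond the scatter), both modest steps. Among these three compounds, then, the unsubstituted sulfamoyl form of compound 3 has the lowest number, which hints that a replacement may sit somewhat higher. Since the new group differs by only a single added carbon in the count, only a small move seems reasonable.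

The expected step is a 1.8-fold higher number from compound 3 to compound 4 (0.24 log units; within the scatter), leaning upward with real uncertainty. For compound 4 the estimated value is 3500 nM, with an expected range from 1200 nM to 10000 nM.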

Compound 4, half-maximal inhibitory concentration: 13000 nM
Beside the measured number, compound 4's estimate is 3.7-fold (0.57 log units) below it, outside the stated range (above it).
By their numbers in this assay, from the lowest: compound 3; then compounds 2, 4 and 1 (each within the scatter of the next).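

In this assay, this swap on the aromatic carbon has a clear effect: a 6.5-fold higher number from compound 3 to compound 4 (0.81 log units; beyond the scatter) appears even though the counts of hydrogen-bond donors and acceptors stay the same and neither a ring nor a net charge is added, so those counts alone do not track the read-out across this pair. The other two new steps, a 1.6-fold higher number from compound 2 to compound 4 (0.21 log units; within the scatter) and a 1.2-fold lower number from compound 1 to compound 4 (0.09 log units; within the scatter), are both within the scatter, so compound 4 cannot be told apart from either of those compounds, and compound 3, with its unsubstituted sulfamoyl, stands alone with the lowest number of the four. Nothing available here explains why the number moves at this position.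

The compounds shown leave open whether the rise from compound 3 comes from the methyl end of methanesulfonamido or from the different way this group is joined to the aromatic carbon. Going by these compounds, how an acetamido group or a plain amine on that same aromatic carbon would read in this assay also remains open.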